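Compound 1 to compound 4: losing the trifluoromethyl

The source may hold more compounds than are shown below. What is called first, only, known or untested is meant among the compounds shown, and "the series" means these compounds.

In a functional assay on HCT-116 cells (Homo sapiens) for antiproliferative activity, read by MTT assay, with a stated time of 72 h (a lower number here means a stronger inhibitor, a higher number a weaker inhibitor), compound 1 `O=C(Nc1ccc(Nc2nccc(NC3CCCC3)n2)cc1)Nc1ccc(Cl)c(C(F)(F)F)c1` gives 2510 nM and sits level with its two neighbours: compound 2 `CCCNc1ccnc(Nc2ccc(NC(=O)Nc3ccc(Cl)c(C(F)(F)F)c3)cc2)n1` gives 4240 nM and compound 3 `O=C(Nc1ccc(Nc2nccc(Nc3ccc(Cl)cc3)n2)cc1)Nc1ccc(Cl)c(C(F)(F)F)c1` gives 4660 nM on the same read-out. These three differ only in the group on a nitrogen on an aromatic ring. The steps are a 1.7-fold higher number from compound 1 to compound 2 (0.23 log units; within the scatter) and a 1.9-fold higher number from compound 1 to compound 3 (0.27 log units; within the scatter) and a 1.1-fold higher number from compound 2 to compound 3 (0.04 log units; within the scatter) and all of them stay within the scatter.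

Compound 4 `O=C(Nc1ccc(Cl)cc1)Nc1ccc(Nc2nccc(NC3CCCC3)n2)cc1` keeps the cyclopentyl of compound 1 and changes a different place: hydrogen in place of trifluoromethyl on an aromatic carbon so that 4-chloro-3-(trifluoromethyl)phenyl becomes 4-chlorophenyl. For the measured compounds named here, no measured step touches this place, so the series gives no direct size for it. The small steps above are only a weak guide. A modest move toward a higher number is expected, with the direction uncertain, and the estimate is a 1.8-fold higher number from compound 1 to compound 4 (0.25 log units; within the scatter) for this change. In this assay compound 4 is estimated at 4500 nM within an expected range of 1800 nM to 12000 nM for now.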

Compound 4, half-maximal inhibitory concentration: 5310 nM
For compound 4 the middle estimate is 1.2-fold (0.07 log units) below the measured one, within the range that was stated.
By their numbers in this assay, from the lowest: compounds 1, 2, 3 and 4 (each within the scatter of the next, the first and the last beyond it).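

For the compounds shown here, removing the trifluoromethyl gives a 2.1-fold higher number from compound 1 to compound 4 (0.33 log units; beyond the scatter) in this assay, the first step to lie beyond the scatter. The earlier steps all changed the group on a nitrogen on an aromatic ring and all stayed within the scatter, so this aromatic carbon is the only place shown where a single change gives a readable, though modest, difference. Nothing measured here bears on why the number moves with this change.

Still open, from the compounds shown here alone, is how a methyl, a fluoro or a nitrile on this same carbon would compare with trifluoromethyl and hydrogen. Also open, going by these compounds, is whether the step holds with propyl or 4-chlorophenyl in place of cyclopentyl, since it is read here only with cyclopentyl on the nitrogen.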